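The source may report more compounds than this note shows. Statements on the series, on what has been measured and on what is new or still open speak of the compounds shown alone.

Compound 1 `COc1cccc(-c2cc(-c3ccc(C4NC(=O)c5ccccc5N4)cc3)nc(N)n2)c1OC`: > 400000 nM
Compound 2 `CCCCNC(c1ccc(C2NC(=O)c3ccccc3N2)cc1)c1nnnn1C(C)(C)C`: "not determined" (no result reported)

These entries come from an ADME assay on Vero cells (Chlorocebus sabaeus) for cytotoxicity, read by MTT assay, with a stated time of 72 h; a lower number here means that less compound is tolerated, a higher number that more compound is tolerated. Compound 1 gives > 400000 nM, which is a limit of the assay and not a number. The record for that compound is therefore (the limit of > 400000 nM in this assay, at which 1 of the 2 values shown sits). Compound 2 has no result to compare, its entry being "not determined" (no result reported).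

Compound 3 `COc1cc(-c2cc(-c3ccc(C4NC(=O)c5ccccc5N4)cc3)nc(N)n2)cc(OC)c1OC` keeps the core of compound 1 and changes one group: 3,4,5-trimethoxyphenyl in place of 2,3-dimethoxyphenyl on an aromatic carbon. A 3,4,5-trimethoxyphenyl takes the place of the 2,3-dimethoxyphenyl, on the aromatic carbon next to the ring nitrogen. Within the data shown here, no measured pair of compounds shows what a change of this kind does in this assay. The expectation rests on compound 1 alone, whose result is the limit > 400000 nM. A modest move towards a lower number is expected, possibly none beyond the scatter, and compound 3 may well return only a limit too. The estimate amounts to an expected step of an at least 1.3-fold lower number from compound 1 to compound 3 (0.12 log units; that floor lies within the scatter). For compound 3 the estimated value is 300000 nM, with an expected range of 80000 nM to 400000 nM.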

Compound 3, half-maximal cytotoxic concentration: 85900 nM
Estimate against measurement, compound 3: 3.5-fold (0.54 log units) above; the range from low to high includes it.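

In this assay, putting 3,4,5-trimethoxyphenyl in place of 2,3-dimethoxyphenyl on the aromatic carbon next to the ring nitrogen gives an at least 4.6-fold lower number from compound 1 to compound 3 (0.66 log units; beyond the scatter), so the group at this position can affect how much compound the cells tolerate. Compound 3 also gives the series its first actual number, 85900 nM, against which later changes at this position can be read. Compound 1 gives > 400000 nM, which is a limit and not a number, and the true size of the step stays unknown because of that limit: the limit of > 400000 nM in this assay, at which 1 of the 3 values shown sits.

This single swap changes both how many methoxy groups the aromatic ring carries and where they sit, so the compounds shown cannot separate the effect of the added methoxy group from the effect of the new arrangement. On these data alone, it also remains open whether an unsubstituted phenyl, or a phenyl carrying an amine or a carboxylic acid, at this position would give a lower or a higher number, and one pair of compounds does not establish a trend for the series.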